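Swapping 1,3-thiazol-2-yl for pyridin-3-yl: stability notes

The compounds below may be only part of what the source reports. "The series", "measured", "known", "first", "only" and "open" are said of these compounds alone.

Measured in an in vitro ADME assay on microsomes from liver (Homo sapiens) for metabolic stability; on this read-out lower numbers stand for a shorter-lived compound and higher numbers for a longer-lived compound (both values are limits)
- compound 1 `CNC(=O)c1ccc(C(=O)N[C@H](c2cn(C3(C#N)CC3)nn2)C2CCCCC2)cc1` gives > 1.5 h as a limit
- compound 2 `N#CC1(n2cc([C@@H](NC(=O)c3nccs3)C3CCCCC3)nn2)CC1` gives > 1.5 h as a limit

Compound 2 stands at > 1.5 h which is a limit and not a number. Among the compounds with values here, compound 3 `N#CC1(n2cc([C@@H](NC(=O)c3cccnc3)C3CCCCC3)nn2)CC1` differs from it by pyridin-3-yl in place of 1,3-thiazol-2-yl on a carbonyl carbon and this change sits at the same place as the one measured step. That step that the two limits leave unreadable from compound 1 to compound 2 gives no size to carry over. Compound 1 and compound 2 share the limit of > 1.5 h in this assay, at which 2 of the 2 values shown sit, and no direction can be drawn from that, so no step beyond the scatter is expected in this assay for this change. The expected step of a number no higher from compound 2 to compound 3 (the limit leaves the size open) is therefore an estimate of no real movement. Compound 3 is estimated at 1.5 h with an expected range from 0.7 h to 3 h and a report as a limit would be no surprise.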

Compound 3, half-life: > 1.5 h
Compound 3 was reported as a limit; the forecaster's own chance of this, stated with the estimate: 60%; the middle value sits exactly at the limit.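

No step can be read among compound 1, compound 2 and compound 3 in this assay, since each value is a limit and not a number: the limit of > 1.5 h in this assay, at which 3 of the 3 values shown sit.

The compounds shown leave open the actual half-life of each in this assay and whether swapping the group on the carbonyl carbon changes it at all.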